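A few compounds are considered here, and "the series" means these few. Any claim that something is new, unique, unknown or untested is made for them only; others in the source may bear on it.

Working notes on the series. Compound 1 `CCCCCCCCCC/N=c1\nc(N)c2ncn(Cc3ccccc3)c2c(N)n1`, compound 2 `CCCCCCCC/N=c1\nc(N)c2ncn(Cc3ccccc3)c2c(N)n1` and compound 3 `CCCCCCCC/N=c1\nc(N)c2ncn(Cc3ccc(OC)cc3)c2c(N)n1` were all run in a functional assay on NCI-H460 cells (Homo sapiens) for antiproliferative activity, read by WST assay, with a stated time of 72 h; on this read-out lower numbers stand for stronger inhibition and higher numbers for weaker inhibition. Compound 1 gives 3200 nM, compound 2 gives 7450 nM and compound 3 gives 4200 nM. Compound 3 thus stands second highest of the three numbers, within the scatter of both others. The chain step a 2.3-fold higher number from compound 1 to compound 2 (0.37 log units; beyond the scatter) lies beyond the scatter, whereas the ring step a 1.8-fold lower number from compound 2 to compound 3 (0.25 log units; within the scatter) stays within it. Compound 4 `CCCCCCCC/N=c1\nc(N)c2ncn(Cc3ccc(F)cc3)c2c(N)n1` differs from compound 3 by fluoro in place of methoxy on an aromatic carbon. Only the ring step from compound 2 to compound 3 bears on this change, and it stayed within the scatter; no step beyond the scatter is therefore expected, with a 1.2-fold higher number from compound 3 to compound 4 (0.08 log units; within the scatter) as the expected change in this assay. For compound 4 the estimate in this assay is 5000 nM, in the range 2500 nM to 10000 nM.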

Compound 4, half-maximal inhibitory concentration: 4700 nM
Estimate against measurement, compound 4: 1.1-fold (0.03 log units) above; low and high end bracket the measured number.
By their numbers in this assay, from the lowest: compounds 1, 3, 4 and 2 (each within the scatter of the next, the first and the last beyond it).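

In this assay fluoro in place of methoxy on the aromatic carbon para to a large group gives a 1.1-fold higher number from compound 3 to compound 4 (0.05 log units; within the scatter) and fluoro in place of hydrogen at the same carbon gives a 1.6-fold lower number from compound 2 to compound 4 (0.20 log units; within the scatter) as well. Hydrogen, methoxy and fluoro at this position thus all stay within the scatter of one another, so this change separates none of them. No supporting data bear on why these numbers lie so close.

Going by these compounds, whether an amine or a carboxylic acid at this position would give a step beyond the scatter remains open. So does whether fluoro behaves the same on the longer chain of compound 1.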